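The compounds below may be only part of what the source reports. "The series", "measured", "known", "first", "only" and "open" are said of these compounds alone.

Three compounds sharing a common core were measured. Compound 1 `COc1cc(N)c(Cl)cc1C(=O)CCC1CCN(CCNS(=O)(=O)c2cc(Br)c(N)c(Br)c2)CC1` gives 83% in an assay on HEK293 cells for displacement of a labelled ligand from 5-hydroxytryptamine receptor 6 (Homo sapiens), with a stated time of 60 min, tested at 1 uM, in the presence of a further agent that is not named here; on this read-out lower numbers stand for a weaker effect and higher numbers for a stronger effect at the one concentration tested. Compound 2 `COc1cc(N)c(Cl)cc1C(=O)CCC1CCN(CCNS(=O)(=O)c2ccc3c(c2)NC(=O)CO3)CC1` gives 40% in this assay, and compound 3 `COc1cc(N)c(Cl)cc1C(=O)CCC1CCN(CCNS(=O)(=O)c2ccc(OC)c(N3CCN(C)CC3)c2)CC1` gives 43%. Compound 2 stands lowest of the three: compound 3 sits within the scatter of it, while compound 1 lies well above it. Within the data shown here, the only single-change step seen so far, a number 43 percentage points lower from compound 1 to compound 2 (beyond the scatter), is large. Compound 4 `COc1cc(N)c(Cl)cc1C(=O)CCC1CCN(CCNS(=O)(=O)c2ccc(N)c(Br)c2)CC1` differs from compound 2 in one place: a group of 8 heavy atoms (6 carbon, 1 nitrogen, 1 bromine; one six-membered aromatic ring of carbon only) in place of a group of 11 heavy atoms (8 carbon, 1 nitrogen, 2 oxygen; one six-membered non-aromatic ring with 2 hetero atoms, one six-membered aromatic ring of carbon only), on a sulfonyl sulfur. The entering group closely resembles the group carried by compound 1 on the sulfonyl sulfur, so that large step bears directly here, and a large rise toward the value of compound 1 is expected. Compound 4 is estimated at 70%, between 50% and 88%. The expected step is a number 30 percentage points higher from compound 2 to compound 4 (beyond the scatter).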

Compound 4, a percentage reported as inhibition, at one concentration (the size of the read-out at that concentration, not a potency): 85%
Compound 4: the middle estimate sits 15 percentage points below what was measured; the measured number falls inside the stated range.
By their numbers in this assay, from the lowest: compounds 2 and 3 (each within the scatter of the next); then compounds 1 and 4 (each within the scatter of the next).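

Putting the 4-amino-3-bromophenyl group on the sulfonyl sulfur in this assay gives a number 45 percentage points higher from compound 2 to compound 4 (beyond the scatter), so this position again responds strongly to the group it carries. Taking away one bromo, with hydrogen in place of bromo on an aromatic carbon, gives only a number 2 percentage points higher from compound 1 to compound 4 (within the scatter), so the high value of compound 1 does not depend on its second bromo. Nothing available explains either step. As far as these compounds go, whether the remaining bromo or the amino group matters stays open. A plain 4-aminophenyl group, or chloro in place of that bromo, would address this.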